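The source may report more compounds than this note shows. Statements on the series, on what has been measured and on what is new or still open speak of the compounds shown alone.

Measured in a functional assay on HCT-116 cells (Homo sapiens); a lower number here means a stronger inhibitor, a higher number a weaker inhibitor:
- Compound 1 `COc1cc(NC(C)CCCNC(=O)NO)c2ncccc2c1`: 57000 nM
- Compound 2 `COC(=O)NCCCC(C)Nc1cc(OC)cc2cccnc12`: > 100000 nM

Compound 2 stands at > 100000 nM, which is a limit of the assay and not a number. Compound 3 `CCOC(=O)NCCCC(C)Nc1cc(OC)cc2cccnc12` differs from it by methyl in place of hydrogen on a saturated chain carbon bound to an oxygen next to a carbonyl group: methyl in place of hydrogen, turning methoxycarbonyl into ethoxycarbonyl. Going by the values given here, the only measured step that bears on this is an at least 1.7-fold higher number from compound 1 to compound 2 (0.24 log units; that floor lies within the scatter). It changed the group on the same carbonyl carbon, and it gives no size for an added methyl. No step beyond the scatter is therefore expected in this assay. The expected change is a number no higher from compound 2 to compound 3 (the limit leaves the size open). Compound 3 is estimated at 100000 nM, with an expected range of 40000 nM to 250000 nM.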

Compound 3, half-maximal inhibitory concentration: 28000 nM
The estimate for compound 3 lay 3.6-fold (0.55 log units) above the measured number; measured number outside the range, below it.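

In this assay methyl in place of hydrogen on a saturated chain carbon bound to an oxygen next to a carbonyl group gives an at least 3.5-fold lower number from compound 2 to compound 3 (0.55 log units; beyond the scatter) and shows that methoxycarbonyl to ethoxycarbonyl alone moves the number. There is also a 2.0-fold lower number from compound 1 to compound 3 (0.31 log units; beyond the scatter) and this shows that hydroxyamino is not needed for the number reached here. The value of compound 2 is a limit of the assay and not a number: the limit of > 100000 nM in this assay, at which 1 of the 3 values shown sits.

Going by these compounds, whether a longer chain such as propoxy on this carbonyl lowers the number further stays open. So does the effect of an amine in place of the oxygen on the carbonyl carbon.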